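The source may report more compounds than this note shows. Statements on the series, on what has been measured and on what is new or still open speak of the compounds shown alone.

Measured in an ADME assay on BJ cells (Homo sapiens) for cytotoxicity, with a stated time of 72 h; a lower number here means that less compound is needed, a higher number that more compound is needed for the effect:
- Compound 1 `Nc1nc(-c2ccccc2)nn1-c1ncnc2cc(Cl)ccc12`: > 50000 nM
- Compound 2 `COc1cc2ncnc(-n3nc(-c4ccccn4)nc3N)c2cc1[N+](=O)[O-]`: > 13000 nM
- Compound 3 `COc1cc2nc(Cl)nc(-n3nc(-c4ccccn4)nc3N)c2cc1OC`: > 13000 nM

Each of these three results is a limit of the assay and not a number. Compound 3 stands at > 13000 nM, which is a limit. So no number yet marks where the series lies.

Compound 4 `COc1cc2nc(N)nc(-n3nc(-c4ccccn4)nc3N)c2cc1OC` has amino in place of chloro on an aromatic carbon, between two ring nitrogen atoms (amino in place of chloro on an aromatic carbon). Among the compounds with values here, no measured pair of compounds shows the size of such a step in this assay, so none beyond the scatter is expected. The expected change is a step that the limit leaves unreadable from compound 3 to compound 4. The assay may well report only a limit again. For compound 4 the estimated value is 15000 nM, with an expected range from 6000 nM to 50000 nM.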

Compound 4, half-maximal effective concentration: > 27000 nM
Compound 4: no number, only a limit (the forecaster's own chance of this, stated with the estimate: 75%); middle value at least 1.8-fold (0.25 log units) from the limit.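

Compound 3 gives > 13000 nM, which is a limit of the assay. Compound 4 gives > 27000 nM, again a limit, so the effect of amino in place of chloro cannot be read. The compounds shown leave open what concentration of any of them would reach half-maximal effect in this assay.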